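The source may report more compounds than this note shows. Statements on the series, on what has been measured and on what is new or still open speak of the compounds shown alone.

Measured compounds:
Compound 1 `COc1cc2c(Nc3ccc(C#N)cc3)ncnc2cc1OCCCN1CCC(C)CC1`: 16600 nM
Compound 2 `COc1cc2c(Nc3cccc(C#N)c3)ncnc2cc1OCCCN1CCC(C)CC1`: 17700 nM

Both compounds were tested in a functional assay on DU-145 cells (Homo sapiens) for antiproliferative activity, read by MTT assay, with a stated time of 72 h; a higher number here means a weaker inhibitor, a lower number a stronger inhibitor. Compound 2 sits at the same level as compound 1: the step of a 1.1-fold higher number from compound 1 to compound 2 (0.03 log units; within the scatter) is within the scatter, so neither can be called the stronger or the weaker of the pair.

Compound 3 `COc1cc2c(Nc3ccccc3C#N)ncnc2cc1OCCCN1CCC(C)CC1` has not yet been measured. It differs from compound 2 in one place: 2-cyanophenyl in place of 3-cyanophenyl on a nitrogen on an aromatic ring. Within the data shown here, the only measured step that bears on this is the earlier move of the nitrile around the same ring, a 1.1-fold higher number from compound 1 to compound 2 (0.03 log units; within the scatter), which produced no change beyond the scatter. Moving the nitrile once more is therefore expected to give no step beyond the scatter in this assay, in either direction, which is a 1.0-fold higher number from compound 2 to compound 3 (0.01 log units; within the scatter). Compound 3 is estimated at 18000 nM, with a range from 8000 nM to 40000 nM.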

Compound 3, half-maximal inhibitory concentration: 11900 nM
The estimate for compound 3 lay 1.5-fold (0.18 log units) above the measured number; low and high end bracket the measured number.
By their numbers in this assay, from the lowest: compounds 3, 1 and 2 (each within the scatter of the next).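

With 2-cyanophenyl now alongside 3-cyanophenyl and 4-cyanophenyl, three placements of the nitrile on this ring can be compared in this assay, and both new steps stay within the scatter: a 1.5-fold lower number from compound 2 to compound 3 (0.17 log units; within the scatter) and a 1.4-fold lower number from compound 1 to compound 3 (0.14 log units; within the scatter). Among these compounds, for these three compounds, then, where the nitrile sits on the ring makes no readable difference to the number, a finding that the single step between compound 1 and compound 2 could not establish across all three placements. Nothing measured here speaks to why the placement has so little effect.

From the compounds shown here alone, it remains open whether the nitrile itself matters, which a plain phenyl ring without it would test. Also open, going by these compounds, is whether an amine or a carboxylic acid in its place would move the number beyond the scatter.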